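A few compounds are considered here, and "the series" means these few. Any claim that something is new, unique, unknown or untested is made for them only; others in the source may bear on it.

Measured compounds in an ADME assay on HCT-116 cells (Homo sapiens) for cytotoxicity, read by CellTiter-Glo, with a stated time of 72 h; on this read-out lower numbers stand for stronger inhibition and higher numbers for weaker inhibition:

Compound 1, `Cc1cc(C)c(S(=O)(=O)N2CCC(C3OCC(C)CO3)CC2)c(C)c1`: > 5000 nM

Compound 2, `COc1ccc(S(=O)(=O)N2CCC(N3CCC(C)CC3)CC2)cc1OC`: > 5000 nM

Compound 3, `Cc1cc(S(=O)(=O)N2CCC(N3CCC(C)CC3)CC2)c(Cl)cc1Cl`: > 5000 nM.

Compound 2 gives in this assay not a number but the limit of the assay, > 5000 nM. The same holds for the other two compounds: for compound 1 the result is the limit > 5000 nM, and for compound 3 it is the limit > 5000 nM. Every result shown therefore sits at the limit of > 5000 nM in this assay, at which 3 of the 3 values shown sit, and compound 2 stands nowhere above or below its companions; the numbers give no ranking among them.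

Compound 4, `COc1cccc(S(=O)(=O)N2CCC(N3CCC(C)CC3)CC2)c1`, has not yet been measured in this assay. It differs from compound 2 in one place: hydrogen in place of methoxy on an aromatic carbon. Going by the values given here, since every compound so far has stopped at the limit, no step in either direction beyond the scatter is expected from compound 2 to compound 4, and a step that the limit leaves unreadable from compound 2 to compound 4 is the estimated change. Compound 4 is expected to give 10000 nM in this assay, with a range from 5000 nM to 50000 nM, most likely reported again only as a limit.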

Compound 4, half-maximal inhibitory concentration: > 5000 nM
Compound 4 was reported as a limit (the forecaster's own chance of this, stated with the estimate: 85%); the middle value does not contradict the limit.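

No step from compound 2 to compound 4 can be read in this assay, since both results are limits: the limit of > 5000 nM in this assay, at which 4 of the 4 values shown sit.

The compounds shown leave open how far each one lies past that limit, and whether hydrogen in place of methoxy changes the result at all.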